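Chalcones in a Griess Read-out: Compound 1 to Compound 3

A few compounds are considered here, and "the series" means these few. Any claim that something is new, unique, unknown or untested is made for them only; others in the source may bear on it.

Measured so far:
compound 1, `COc1cc(OC)c(OC)cc1/C=C/C(=O)c1cc(Cl)ccc1O`: 2.32 ug/mL
compound 2, `COc1cc(OC)c(OC)cc1/C=C/C(=O)c1cccc(C(F)(F)F)c1`: 2.09 ug/mL

Two compounds of this set have been run in a functional assay, read by Griess assay, with a stated time of 2.5 h; a lower number here means a stronger inhibitor, a higher number a weaker inhibitor. Compound 1 gives 2.32 ug/mL, and compound 2 gives 2.09 ug/mL. Going by the values given here, compound 1 holds the higher of the two numbers, but its only neighbour, compound 2, lies within the usual scatter, so the two cannot be told apart on these data. Among the compounds with values here, no measured pair differs in only one place, so no single step has yet been observed.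

Compound 3 `COc1cc(OC)c(OC)cc1/C=C/C(=O)c1ccc(F)cc1` is still to be measured in this assay. Against compound 1 the change is 4-fluorophenyl in place of 5-chloro-2-hydroxyphenyl on a carbonyl carbon. The measured values of compound 1 and compound 2 show that two rather different rings on the carbonyl carbon gave numbers within the scatter, which leaves the direction of this step open; a small step, if any, toward a somewhat higher number is expected for compound 3. The expected step is a 1.4-fold higher number from compound 1 to compound 3 (0.14 log units; within the scatter). Compound 3 is estimated at 3.2 ug/mL, with a range from 1.3 ug/mL to 8 ug/mL.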

Compound 3, half-maximal inhibitory concentration: 1.96 ug/mL
Compound 3: middle estimate off by 1.6-fold (0.21 log units), on the high side; the range from low to high includes it.
By their numbers in this assay, from the lowest: compounds 3, 2 and 1 (each within the scatter of the next).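

In this assay, going by these compounds alone, 4-fluorophenyl in place of 5-chloro-2-hydroxyphenyl on the carbonyl carbon gives a 1.2-fold lower number from compound 1 to compound 3 (0.07 log units; within the scatter) and is the first single change at this place that can be read, and it cannot be told apart from no change at all. The group that leaves counts a hydrogen-bond donor and a hydrogen-bond acceptor and the group that enters counts neither, yet the read-out does not separate compound 1 from compound 3, so across this one pair those counts show no link to the number. No measurement of any other kind is at hand that could explain why the step is this small.

From the compounds shown here alone, the three compounds share their core and differ only in the ring on the carbonyl carbon, so it stays open what a ring carrying an amine or a carboxylic acid would do at this place, and whether any ring here can move the number beyond the scatter. Equally open is how the number responds to a change elsewhere in the shared core, since every compound shown keeps that part the same.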